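Amide substituent swap on the shared core: clearance outlook

A few compounds are considered here, and "the series" means these few. Any claim that something is new, unique, unknown or untested is made for them only; others in the source may bear on it.

Compound 1 `CN1C[C@H](C(=O)Nc2ccc(C(F)(F)F)cc2)[C@@H](c2ccc(/C=C/C(=O)Nc3ccccc3N)cc2)C1` is the benchmark here. In an in vitro ADME assay on microsomes from liver (Mus musculus) for pharmacokinetics, read by LC-MS, with a stated time of 10 min, tested at 1 uM (on this read-out higher numbers stand for fast clearance and lower numbers for slow clearance), compound 1 gives 23 mL/min/kg, the lowest of the three numbers; compound 2 `CN1C[C@H](C(=O)Nc2cccc(Cl)c2)[C@@H](c2ccc(/C=C/C(=O)Nc3ccccc3N)cc2)C1` gives 58 mL/min/kg and compound 3 `Cc1ccc(NC(=O)[C@H]2CN(C)C[C@@H]2c2ccc(/C=C/C(=O)Nc3ccccc3N)cc2)cn1` gives 57 mL/min/kg. Both neighbours sit beyond the scatter from compound 1: a 2.5-fold higher number from compound 1 to compound 2 (0.40 log units; beyond the scatter) and a 2.5-fold higher number from compound 1 to compound 3 (0.39 log units; beyond the scatter), while a 1.0-fold lower number from compound 2 to compound 3 (0.01 log units; within the scatter). Compound 4 `CN1C[C@H](C(=O)NC2CC2)[C@@H](c2ccc(/C=C/C(=O)Nc3ccccc3N)cc2)C1` differs from compound 1 by cyclopropyl in place of 4-(trifluoromethyl)phenyl on an amide-type nitrogen. Among the compounds with values here, no measured step exchanges the aryl group for a non-aromatic ring, so the two steps from compound 1 are only loose guides; each replacement of 4-(trifluoromethyl)phenyl raised clearance modestly. A modest rise, or none beyond the scatter, is expected for compound 4, that is a 1.7-fold higher number from compound 1 to compound 4 (0.22 log units; within the scatter). Compound 4 is therefore estimated at 38 mL/min/kg, within 16 mL/min/kg to 90 mL/min/kg.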

Compound 4, clearance: 7 mL/min/kg
Beside the measured number, compound 4's estimate is 5.4-fold (0.73 log units) above it, outside the stated range (below it).
By their numbers in this assay, from the lowest: compound 4; then compound 1; then compounds 3 and 2 (each within the scatter of the next).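

At this amide-type nitrogen, only the non-aromatic ring lowers clearance (a 3.3-fold lower number from compound 1 to compound 4 (0.52 log units; beyond the scatter)), whereas both aryl replacements of 4-(trifluoromethyl)phenyl raised it. The gap is wider against those two aryl groups (an 8.1-fold lower number from compound 3 to compound 4 (0.91 log units; beyond the scatter); an 8.3-fold lower number from compound 2 to compound 4 (0.92 log units; beyond the scatter)), which places cyclopropyl lowest of the four, with all its steps beyond the scatter. Nothing available here accounts for this fall.

From the compounds shown here alone, whether it belongs to cyclopropyl alone or extends to other non-aromatic groups stays open. Cyclobutyl, a longer alkyl chain or a chain carrying an amine at this nitrogen would help to separate these readings.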